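The source may hold more compounds than are shown below. What is called first, only, known or untested is meant among the compounds shown, and "the series" means these compounds.

Values in a functional assay on HeLa S3 cells (Homo sapiens) for antiproliferative activity, read by XTT assay, with a stated time of 72 h; a higher number here means a weaker inhibitor, a lower number a stronger inhibitor:
Compound 1 `CSc1ncnc2c1c(-c1ccoc1)cn2[C@@H]1O[C@H](CO)[C@@H](O)[C@H]1O`: 5390 nM
Compound 2 `CSc1ncnc2c1c(-c1ccsc1)cn2[C@@H]1O[C@H](CO)[C@@H](O)[C@H]1O`: > 20000 nM (a limit)
Compound 3 `CSc1ncnc2c1c(-c1ccccc1)cn2[C@@H]1O[C@H](CO)[C@@H](O)[C@H]1O`: > 20000 nM (a limit)

Compound 3 gives only a limit, > 20000 nM, and no number of its own. This is the limit of > 20000 nM in this assay, at which 2 of the 3 values shown sit.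

Compound 4 `C#Cc1cn([C@@H]2O[C@H](CO)[C@@H](O)[C@H]2O)c2ncnc(SC)c12` keeps the shared core and changes one group, with ethynyl in place of phenyl on an aromatic carbon.

The measured steps all change the group at this same carbon. They show an at least 3.7-fold higher number from compound 1 to compound 2 (0.56 log units; beyond the scatter) and an at least 3.7-fold higher number from compound 1 to compound 3 (0.56 log units; beyond the scatter), so the choice of group can move the result in this assay. The third, a step that the two limits leave unreadable from compound 2 to compound 3, adds nothing on size. Going by the values given here, no measured compound carries ethynyl, so any forecast is loose. Compound 1 alone gives a number, 5390 nM, and that is the best guide available. A modest fall in the number is expected, although compound 4 could also stay at the limit.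

The expected change is an at least 3.3-fold lower number from compound 3 to compound 4 (0.52 log units; beyond the scatter). For compound 4 the estimate is 6000 nM, with an expected range of 800 nM to 30000 nM.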

Compound 4, half-maximal inhibitory concentration: 110 nM
Compound 4: middle estimate off by 55-fold (1.74 log units), on the high side, and the stated range ends above it.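

In this assay, the group on this carbon can do far more than the three ring-bearing compounds revealed: ethynyl in place of a ring gives an at least 180-fold lower number from compound 3 to compound 4 (2.25 log units; beyond the scatter), an at least 180-fold lower number from compound 2 to compound 4 (2.25 log units; beyond the scatter) and a 49-fold lower number from compound 1 to compound 4 (1.69 log units; beyond the scatter). Earlier, the only readable differences were among aromatic rings, and compound 4 now shows that a group with no ring and a triple bond can sit here with a much lower number than any of them. Compounds 2 and 3 give only limits, so the first two steps are minimum sizes: the limit of > 20000 nM in this assay, at which 2 of the 4 values shown sit.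

As far as these compounds go, whether the triple bond or the absence of a ring carries this step remains open. An ethyl chain, a vinyl group or a nitrile on the same carbon would each leave a different part of that question to be tested.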